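A few compounds are considered here, and "the series" means these few. Any claim that something is new, unique, unknown or untested is made for them only; others in the source may bear on it.

Measured so far in a functional assay on K562 cells (Homo sapiens) for inhibition, read by MTT assay, with a stated time of 72 h; on this read-out higher numbers stand for weaker inhibition and lower numbers for stronger inhibition:
compound 1 `CC(C)(C)c1ccc(C(=O)/C=C/C(=O)O)cc1` gives 4330 nM
compound 2 `O=C(O)/C=C/C(=O)c1ccc(Br)cc1` gives 11200 nM

Among the measured compounds shown here, compound 2 stands at the highest of the two numbers; compound 1 is its only neighbour, and the step between them, a 2.6-fold higher number from compound 1 to compound 2 (0.41 log units; beyond the scatter), came from exchanging one group on the ring. Compound 3 `O=C(O)/C=C/C(=O)c1ccc(Cl)cc1` differs from compound 2 by chloro in place of bromo on an aromatic carbon. For the measured compounds named here, no measured step bears directly on this change: the one known step exchanges tert-butyl for bromo, not bromo for chloro. With no guide, a step within the scatter in this assay is expected, a 1.1-fold higher number from compound 2 to compound 3 (0.03 log units; within the scatter). Compound 3 is thus estimated at 12000 nM, in a range from 5500 nM to 27000 nM.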

Compound 3, half-maximal inhibitory concentration: 21700 nM
Estimate against measurement, compound 3: 1.8-fold (0.26 log units) below, and the stated range covers the measured number.
By their numbers in this assay, from the lowest: compound 1; then compounds 2 and 3 (each within the scatter of the next).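

Exchanging bromo for chloro at this ring position gives a 1.9-fold higher number from compound 2 to compound 3 (0.29 log units; within the scatter) and so does not separate the two halogens in this cell test. The step away from tert-butyl is clearer: a 5.0-fold higher number from compound 1 to compound 3 (0.70 log units; beyond the scatter) shows that, with chloro as with bromo, compound 1 keeps the lowest number of the three. No measurement here accounts for these differences.

Still open, on these data alone, is how fluoro, an amine or a longer alkyl chain at this position would compare with tert-butyl and the two halogens.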